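This account rests on a few compounds, and the source may have more. Where it says the series, first, only, none or still open, it means among the compounds named here.

The series shares one core. In a functional assay on aorta for antagonist activity at Alpha-1D adrenergic receptor (Rattus norvegicus) (on this read-out higher numbers stand for weaker binding and lower numbers for tighter binding), compound 1 `COc1ccccc1N1CCN(CCCNc2ncccc2C(=O)NC(C)(C)C)CC1` gives 10 nM; compound 2 `COc1ccccc1N1CCN(CCCNc2ncccc2C(=O)N(C)C)CC1` gives 20 nM; compound 3 `CSc1ccccc1N1CCN(CCCNc2ncccc2C(=O)N(C)C)CC1` gives 31.6 nM. Among the measured compounds shown here, on the numbers so far compound 2 stands nearest to compound 3 and furthest from compound 1, yet both steps around it, a 2.0-fold higher number from compound 1 to compound 2 (0.30 log units; within the scatter) and a 1.6-fold higher number from compound 2 to compound 3 (0.20 log units; within the scatter), lie within the scatter, so nothing separates the three beyond repeat variation.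

Compound 4 `CN(C)C(=O)c1cccnc1NCCCN1CCN(c2ccccc2C2CC2)CC1` is not yet measured. It differs from compound 2 as follows: cyclopropyl in place of methoxy on an aromatic carbon. The measured step that bears most directly on this is the one at the same place, methylsulfanyl in place of methoxy on an aromatic carbon, which gave a 1.6-fold higher number from compound 2 to compound 3 (0.20 log units; within the scatter); the exchange on the carbonyl carbon, a 2.0-fold higher number from compound 1 to compound 2 (0.30 log units; within the scatter), also stayed within the scatter. The present change is larger in kind, since the hydrogen-bond acceptor of the methoxy leaves and a three-membered ring of carbon only enters, so a modest rise is expected, a 2.0-fold higher number from compound 2 to compound 4 (0.30 log units; within the scatter), possibly just beyond the scatter. Compound 4 is thus expected to give 40 nM, within a range from 12 nM to 130 nM.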

Compound 4, dissociation constant: 63.1 nM
For compound 4 the middle estimate is 1.6-fold (0.20 log units) below the measured one, within the range that was stated.
By their numbers in this assay, from the lowest: compounds 1, 2, 3 and 4 (each within the scatter of the next, the first and the last beyond it).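

Cyclopropyl in place of methoxy, on an aromatic carbon ortho to a large group, gives a 3.2-fold higher number from compound 2 to compound 4 (0.50 log units; beyond the scatter), the first single-place step in this assay to lie beyond the scatter, so replacements at this position are not all equivalent. Set against methylsulfanyl, the same cyclopropyl gives a 2.0-fold higher number from compound 3 to compound 4 (0.30 log units; within the scatter), so these two replacements of methoxy remain unseparated. The compounds shown come with no measurement that would explain the step.

Open, on these data alone, is whether the three-membered ring itself or the departure of methoxy accounts for the step, a question that isopropyl or ethoxy at this position would address. Also open, as far as these compounds go, is whether the same exchange gives a step of similar size when the tert-butyl amide of compound 1 replaces the dimethyl amide.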